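Aryl replacement on the shared core: compound 2 to compound 3

The source may hold more compounds than are shown below. What is called first, only, known or untested is meant among the compounds shown, and "the series" means these compounds.

Measured so far:
compound 1 `CCOC(=O)c1sc2nc(SC)nc(-c3cccc(OC)c3)c2c1N`, "not determined" (no result reported) in a functional assay on HEK293 cells for agonist activity at lutropin-choriogonadotropic hormone receptor (Homo sapiens), read by cAMP accumulation; a higher number here means that more compound is needed for the effect, a lower number that less compound is needed
compound 2 `CSc1nc(-c2cccc(F)c2)c2c(N)c(C(=O)NC(C)(C)C)sc2n1`, 1200 nM in this assay

Going by the values given here, compound 2 carries the only number in this assay; compound 1 stands beside it without a result, so compound 2 cannot be ranked against anything. Among the compounds with values here, no step between two measured compounds exists here, and nothing is known about how a change on the aryl group moves the read-out.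

Compound 3 `COc1cccc(-c2nc(SC)nc3sc(C(=O)NC(C)(C)C)c(N)c23)c1F` differs from compound 2 in one place: 2-fluoro-3-methoxyphenyl in place of 3-fluorophenyl on an aromatic carbon. Compound 1 also carries a methoxy on its aryl group, but with no value for compound 1 that gives no guidance.

Within the data shown here, with no measured step to lean on, the step from compound 2 to compound 3 in this assay is expected to be small, a 1.2-fold lower number from compound 2 to compound 3 (0.08 log units; within the scatter), not clearly beyond the scatter in either direction. For compound 3 the estimated value in this assay is 1000 nM, with a range from 300 nM to 4000 nM that allows for the unknown effect of the new aryl group.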

Compound 3, half-maximal effective concentration: 1500 nM
Compound 3: the middle estimate sits 1.5-fold (0.18 log units) below what was measured; the measured number falls inside the stated range.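

Going by these compounds alone, with a 1.3-fold higher number from compound 2 to compound 3 (0.10 log units; within the scatter) in this assay, 2-fluoro-3-methoxyphenyl in place of 3-fluorophenyl on this aromatic carbon gives the series its only measured step, and that step does not separate the two compounds. This position therefore accepts the 2-fluoro-3-methoxyphenyl group, with its additional heavy atoms and one hydrogen-bond acceptor, without a read-out change beyond the scatter. Nothing at hand explains this result.

Within the data shown here, compound 1 has no reported result, so steps involving it cannot be read, and the single step available does not separate what the methoxy contributes from what the fluorine contributes, since both differ at once between the two aryl groups. Also open, from the compounds shown here alone, is whether an aryl group carrying an amine or a carboxylic acid, or a pyridine ring in place of the phenyl ring, would move the number beyond the scatter in either direction.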